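Lengthening the unsaturated amide chain in this set

The source may report more compounds than this note shows. Statements on the series, on what has been measured and on what is new or still open speak of the compounds shown alone.

Compound 1: `C=CC(=O)Nc1cccc(Oc2nc(Nc3cccc(C#N)c3)nc3ccsc23)c1` — > 50000 nM
Compound 2: `C/C=C/C(=O)Nc1cccc(Oc2nc(Nc3cccc(C#N)c3)nc3ccsc23)c1` — 47900 nM

Compound 1 `C=CC(=O)Nc1cccc(Oc2nc(Nc3cccc(C#N)c3)nc3ccsc23)c1` reaches only a limit of the assay in an ADME assay on L02 cells (Homo sapiens) for inhibition, read by MTT assay, with a stated time of 72 h (on this read-out lower numbers stand for stronger inhibition and higher numbers for weaker inhibition), namely > 50000 nM. Going by the values given here, compound 2 `C/C=C/C(=O)Nc1cccc(Oc2nc(Nc3cccc(C#N)c3)nc3ccsc23)c1` gives 47900 nM in this assay, the only number in the set. The step of an at least 1.0-fold lower number from compound 1 to compound 2 (0.01 log units; that floor lies within the scatter) lies within the scatter. Compound 1 sits at the limit of > 50000 nM in this assay, at which 1 of the 2 values shown sits. Compound 3 `CC(C)=CC(=O)Nc1cccc(Oc2nc(Nc3cccc(C#N)c3)nc3ccsc23)c1` differs from compound 2 by 2-methylprop-1-en-1-yl in place of prop-1-en-1-yl on a carbonyl carbon. Among the compounds with values here, the one measured step, which touched the same carbonyl carbon, was flat, so no step beyond the scatter is expected in this assay. Compound 3 is therefore expected to give 48000 nM, with a range from 20000 nM to 120000 nM. This is an expected step of a 1.0-fold higher number from compound 2 to compound 3 (0.00 log units; within the scatter), and a limit rather than a number is quite possible.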

Compound 3, half-maximal inhibitory concentration: > 50000 nM
Compound 3: a limit, no number; the forecaster's own chance of this, stated with the estimate: 50%; at least 1.0-fold (0.01 log units) between middle value and limit.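

In this assay compound 3 gives > 50000 nM, a limit of the assay and not a number. The readable step is an at least 1.0-fold higher number from compound 2 to compound 3 (0.01 log units; that floor lies within the scatter), and the step joining the two limits cannot be read, so no change beyond the scatter can be shown for either replacement on this carbonyl carbon. The limit now holds most of the set: the limit of > 50000 nM in this assay, at which 2 of the 3 values shown sit.

From the compounds shown here alone, how far past the limit compound 1 and compound 3 lie stays open. So does whether a longer chain carrying an amine on this carbonyl carbon would give a clearly lower number in this assay.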